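Bromohydroxyphenyl Variant of a Dichlorophenyl Acylhydrazone Urea

The compounds below may be only part of what the source reports. "The series", "measured", "known", "first", "only" and "open" are said of these compounds alone.

Measured compounds:
compound 1 `CN(C)CCn1cnnc1-c1cc(Oc2ccc(NC(=O)N/N=C/c3cccc(O)c3)cc2F)ccn1` 1370 nM
compound 2 `CN(C)CCn1cnnc1-c1cc(Oc2ccc(NC(=O)N/N=C/c3cccc(Cl)c3Cl)cc2F)ccn1` 51 nM
compound 3 `CN(C)CCn1cnnc1-c1cc(Oc2ccc(NC(=O)N/N=C/c3cc(C(C)(C)C)cc(C(C)(C)C)c3O)cc2F)ccn1` 3300 nM

In a functional assay on MKN-45 cells (Homo sapiens) for cytotoxicity, read by MTT assay, with a stated time of 72 h (a lower number here means a stronger inhibitor, a higher number a weaker inhibitor), compound 2 gives the lowest of the three numbers; compound 1 is nearer to it and compound 3 furthest, both beyond the scatter. Compound 4 `CN(C)CCn1cnnc1-c1cc(Oc2ccc(NC(=O)N/N=C/c3ccc(O)c(Br)c3)cc2F)ccn1` differs from compound 2 by 3-bromo-4-hydroxyphenyl in place of 2,3-dichlorophenyl on a carbon with a double bond to nitrogen. Among the measured compounds shown here, the only step that bears on it is a 27-fold lower number from compound 1 to compound 2 (1.43 log units; beyond the scatter), in which a hydroxyl-bearing ring gave way to a dichlorinated one and the number fell greatly. Compound 4 keeps one halogen but restores a hydroxyl, so a rise in this assay relative to compound 2 is expected, though smaller than that step. Compound 4 is therefore estimated at 400 nM (range 120 nM to 1500 nM), an expected step of a 7.8-fold higher number from compound 2 to compound 4 (0.89 log units; beyond the scatter).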

Compound 4, half-maximal inhibitory concentration: 1860 nM
Compound 4: middle estimate off by 4.7-fold (0.67 log units), on the low side, outside the stated range (above it).
By their numbers in this assay, from the lowest: compound 2; then compounds 1, 4 and 3 (each within the scatter of the next, the first and the last beyond it).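

In this assay the bromine in 3-bromo-4-hydroxyphenyl does not keep the low number of the 2,3-dichlorophenyl ring, with a 36-fold higher number from compound 2 to compound 4 (1.56 log units; beyond the scatter) on this carbon with a double bond to nitrogen. Adding bromine to a hydroxyl-bearing ring gives no separation, with a 1.4-fold higher number from compound 1 to compound 4 (0.13 log units; within the scatter), so compound 4 stands with compound 1 and well apart from compound 2. No measurement shown explains this gap. As far as these compounds go, whether the hydroxyl or the bromine sets the number stays open. A 3-bromophenyl group, or a methoxy group in place of the hydroxyl, would help separate the two.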